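The source may hold more compounds than are shown below. What is called first, only, known or untested is meant among the compounds shown, and "the series" means these compounds.

In a toxicity assay on MT2 cells (Homo sapiens) for cytotoxicity, read by XTT assay, with a stated time of 4 days (on this read-out lower numbers stand for higher toxicity in this test and higher numbers for lower toxicity in this test), the three measured compounds stand as follows:

- compound 1 `Cc1nc(C)c([C@H](OC(C)(C)C)C(=O)O)c(N2CCC(C)(C)CC2)c1-c1ccc(-c2ccccc2)cc1`: >= 20000 nM, a limit of the assay rather than a number
- compound 2 `Cc1nc(C)c([C@H](OC(C)(C)C)C(=O)O)c(N2CCC(C)(C)CC2)c1-c1ccc(Oc2ccccc2)cc1`: >= 20000 nM, again a limit of the assay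
- compound 3 `Cc1nc(C)c([C@H](OC(C)(C)C)C(=O)O)c(N2CCC(C)(C)CC2)c1-c1ccc(OCCc2ccc(F)c(F)c2)cc1`: >= 33500 nM, also a limit of the assay

Compound 2 therefore shows no measurable cell toxicity up to the highest concentration tested, and it shares that position with two further values that are likewise only limits; this is the limit of >= 20000 nM in this assay, at which 2 of the 3 values shown sit, while compound 3 sits at the limit of >= 33500 nM in this assay, at which 1 of the 3 values shown sits.

The new compound 4 `Cc1nc(C)c([C@H](OC(C)(C)C)C(=O)O)c(N2CCC(C)(C)CC2)c1-c1ccc(OCCc2ccccn2)cc1` differs from compound 2 in one place: 2-(pyridin-2-yl)ethyl in place of phenyl on an oxygen on an aromatic ring.

The steps measured so far are all unreadable in size. From compound 1 to compound 2 the step is a step that the two limits leave unreadable from compound 1 to compound 2, from compound 1 to compound 3 it is a step that the two limits leave unreadable from compound 1 to compound 3, and the closest comparison, from compound 2 to compound 3, is a step that the two limits leave unreadable from compound 2 to compound 3. That last step changes the same oxygen-bound phenyl for a larger group, much as the present change does, and both ends stay at a limit.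

Compound 4 is therefore expected to remain at a limit in this assay, with an estimated step that the limit leaves unreadable from compound 2 to compound 4 from compound 2.

The expected value for compound 4 is 30000 nM, with a range from 15000 nM to 60000 nM.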

Compound 4, half-maximal cytotoxic concentration: >= 25000 nM
Compound 4: no number, only a limit; the forecaster's own chance of this, stated with the estimate: 85%; the middle value lies beyond the limit too.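

In this assay, compound 4 gives only a limit, as do compound 1, compound 2 and compound 3, so the size of its steps from these three compounds cannot be read. The compounds shown leave open whether 2-(pyridin-2-yl)ethyl in place of phenyl changes cell toxicity at all, and at what concentration any of these compounds becomes toxic.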